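A new group on the aromatic nitrogen of compound 3

The source may hold more compounds than are shown below. What is called first, only, known or untested is meant among the compounds shown, and "the series" means these compounds.

Read-outs in an in vitro ADME assay on microsomes from liver (Homo sapiens) for metabolic stability, tested at 5 uM; on this read-out higher numbers stand for a longer-lived compound and lower numbers for a shorter-lived compound:
Compound 1 `CC(C)(C)CCn1nc(-c2cccs2)c(O)c(C2=NS(=O)(=O)c3cc(NS(C)(=O)=O)ccc3N2)c1=O`: > 1 h, a limit.
Compound 2 `COC(C)(C)CCn1nc(-c2cccs2)c(O)c(C2=NS(=O)(=O)c3cc(NS(C)(=O)=O)ccc3N2)c1=O`: > 1 h, a limit.
Compound 3 `CCC(C)n1nc(-c2cccs2)c(O)c(C2=NS(=O)(=O)c3cc(NS(C)(=O)=O)ccc3N2)c1=O`: > 1 h, a limit.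

Compound 3 sits at the limit of > 1 h in this assay, at which 3 of the 3 values shown sit, so it has no number of its own. Compound 4 `CS(=O)(=O)Nc1ccc2c(c1)S(=O)(=O)N=C(c1c(O)c(-c3cccs3)nn(CC3(C(F)(F)F)CC3)c1=O)N2` carries (1-(trifluoromethyl)cyclopropyl)methyl in place of sec-butyl on an aromatic nitrogen. The measured changes at that place are a step that the two limits leave unreadable from compound 1 to compound 3 and a step that the two limits leave unreadable from compound 2 to compound 3. Neither gives a size or a direction to carry over. The expectation in this assay is therefore no step beyond the scatter, an estimated step that the limit leaves unreadable from compound 3 to compound 4. Compound 4 is expected at an estimated 1.5 h, within 0.7 h to 4 h, and it will probably be reported as a limit again.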

Compound 4, half-life: > 1 h
Compound 4: only a limit was reported; the forecaster's own chance of this, stated with the estimate: 85%; the middle value lies beyond the limit too.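

In this assay, within the data shown here, compound 4 is reported only as a limit, as are compound 1, compound 2 and compound 3, so no step among them can be read: the limit of > 1 h in this assay, at which 4 of the 4 values shown sit. The compounds shown leave open how long each actually lasts, and whether the groups on the aromatic nitrogen differ at all.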